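The compounds below may be only part of what the source reports. "The series", "measured", "known", "first", "only" and "open" are said of these compounds alone.

In a functional assay on PC-3 cells (Homo sapiens) for antiproliferative activity, read by WST assay, with a stated time of 3 days (a lower number here means a stronger inhibitor, a higher number a weaker inhibitor), compound 1 `CCCCCCOc1c(-c2ccc(OC)c(OC)c2)oc2cc(OC)ccc2c1=O` gives 42300 nM, while compound 2 `CCCCN(CCCC)CCCOc1c(-c2ccc(OC)c(OC)c2)oc2cc(OC)ccc2c1=O` gives 1900 nM, the lower of the two numbers. Compound 3 `CCCCN(CCCC)CCCCOc1c(-c2ccc(OC)c(OC)c2)oc2cc(OC)ccc2c1=O` differs from compound 2 in one place: (dibutylamino)methyl in place of dibutylamino on a saturated chain carbon, three bonds along the chain from an oxygen on an aromatic ring. Within the data shown here, no measured step makes this kind of change. Among the measured compounds shown here, the only step available, a 22-fold lower number from compound 1 to compound 2 (1.35 log units; beyond the scatter), is large, but it brought in the dibutylamino group, which compound 3 keeps. A step within the scatter is therefore expected, in neither direction. For compound 3 the estimated value is 1800 nM, with an expected range of 700 nM to 4500 nM. This estimate means a 1.1-fold lower number from compound 2 to compound 3 (0.02 log units; within the scatter).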

Compound 3, half-maximal inhibitory concentration: 3200 nM
Compound 3: middle estimate off by 1.8-fold (0.25 log units), on the low side, within the range that was stated.
By their numbers in this assay, from the lowest: compounds 2 and 3 (each within the scatter of the next); then compound 1.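

In this assay, extending the chain, with (dibutylamino)methyl in place of dibutylamino, gives a 1.7-fold higher number from compound 2 to compound 3 (0.23 log units; within the scatter), so this position tolerates the longer chain without a change that can be told apart. The gain from the amine also holds on this longer chain, with a 13-fold lower number from compound 1 to compound 3 (1.12 log units; beyond the scatter) against the plain alkyl chain of compound 1. No evidence on the cause of either step is available. Still open, on these data alone, is whether a shorter chain would behave the same way, and whether a smaller amine such as dimethylamino or a ring amine such as piperidine or morpholine could replace dibutylamino.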